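A Dichlorophenyl Swap in a Weakly Active Triazole Series

The source may hold more compounds than are shown below. What is called first, only, known or untested is meant among the compounds shown, and "the series" means these compounds.

In a functional assay on MCF7 cells (Homo sapiens) for antiproliferative activity, read by MTT assay, with a stated time of 48 h (a higher number here means a weaker inhibitor, a lower number a stronger inhibitor), three compounds built on one shared core have been tested so far. Compound 1 `N#CC1=C(N)Oc2c(N)cc3nc4ccccc4nc3c2C12C(=O)N(Cc1cnnn1-c1ccc(Cl)cc1)c1ccccc12` carries a 4-chlorophenyl group on an aromatic nitrogen. Compound 1 gives > 50000 nM, which is a limit of the assay rather than a number. Compound 2 `N#CC1=C(N)Oc2c(N)cc3nc4ccccc4nc3c2C12C(=O)N(Cc1cnnn1-c1ccccc1Br)c1ccccc12` carries a 2-bromophenyl group in the same place and gives 30700 nM. Compound 3 `N#CC1=C(N)Oc2c(N)cc3nc4ccccc4nc3c2C12C(=O)N(Cc1cnnn1-c1c(F)cccc1F)c1ccccc12` carries a 2,6-difluorophenyl group there. Compound 3 gives > 50000 nM, again a limit of the assay rather than a number. Compound 3 therefore stands at the edge of what the assay can report, the point described by the limit of > 50000 nM in this assay, at which 2 of the 3 values shown sit. The measured steps are an at least 1.6-fold lower number from compound 1 to compound 2 (0.21 log units; that floor lies within the scatter), an at least 1.6-fold higher number from compound 2 to compound 3 (0.21 log units; that floor lies within the scatter) and a step that the two limits leave unreadable from compound 1 to compound 3. Compound 4 `N#CC1=C(N)Oc2c(N)cc3nc4ccccc4nc3c2C12C(=O)N(Cc1cnnn1-c1cc(Cl)ccc1Cl)c1ccccc12` is not yet measured and differs from compound 3 by 2,5-dichlorophenyl in place of 2,6-difluorophenyl on an aromatic nitrogen. For the measured compounds named here, the steps so far show only that the 2-bromophenyl compound reaches a readable number while the other two do not, so for compound 4 the expectation is an at least 1.2-fold lower number from compound 3 to compound 4 (0.09 log units; that floor lies within the scatter), a step that cannot be called beyond the scatter. Compound 4 is estimated at 40000 nM, within a range from 12000 nM to 50000 nM.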

Compound 4, half-maximal inhibitory concentration: 33200 nM
Estimate against measurement, compound 4: 1.2-fold (0.08 log units) above; the measured number falls inside the stated range.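

For the compounds shown here, the 2,5-dichlorophenyl group also gives a readable number in this assay, so the 2-bromophenyl group is no longer the only group at this position to do so, and the comparison with compound 2 shows a 1.1-fold higher number from compound 2 to compound 4 (0.03 log units; within the scatter). Against the two compounds without a readable number, the change gives an at least 1.5-fold lower number from compound 3 to compound 4 (0.17 log units; that floor lies within the scatter) and an at least 1.5-fold lower number from compound 1 to compound 4 (0.17 log units; that floor lies within the scatter), so neither step is shown to exceed the scatter. Compound 1 and compound 3 therefore remain at a limit and not at a number: the limit of > 50000 nM in this assay, at which 2 of the 4 values shown sit.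

From the compounds shown here alone, all four groups on this phenyl ring are halogen-bearing, so what a methoxy group or an amine would do there remains open. Going by these compounds, the true distance of compound 1 and compound 3 from compound 4 also remains open.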